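The source may hold more compounds than are shown below. What is called first, only, known or untested is meant among the compounds shown, and "the series" means these compounds.

Three measured compounds share one core and differ only in the group carried on the sulfonyl sulfur. Compound 1 `COc1ccc([C@H]2CC(=O)N(c3cccc(NS(=O)(=O)c4cccc(OC(F)(F)F)c4)c3)C2)cc1OC1CCCC1`, compound 2 `COc1ccc([C@H]2CC(=O)N(c3cccc(NS(=O)(=O)c4cccc(Cl)c4C)c3)C2)cc1OC1CCCC1` and compound 3 `COc1ccc([C@H]2CC(=O)N(c3cccc(NS(=O)(=O)c4ccccc4F)c3)C2)cc1OC1CCCC1` were all tested in a functional assay on HEK293 cells (Homo sapiens) for cytotoxicity; a higher number here means that more compound is tolerated, a lower number that less compound is tolerated. Compound 1 gives > 10000 nM in this assay, which is a limit of the assay rather than a number. Compound 2 gives > 10000 nM in this assay, again a limit. Compound 3 gives > 10000 nM in this assay, also a limit. Compound 3 therefore stands where the other two stand, at the limit of > 10000 nM in this assay, at which 3 of the 3 values shown sit. With both ends sitting at a limit, the steps a step that the two limits leave unreadable from compound 1 to compound 2, a step that the two limits leave unreadable from compound 1 to compound 3 and a step that the two limits leave unreadable from compound 2 to compound 3 have no readable size.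

Compound 4 `COc1ccc([C@H]2CC(=O)N(c3cccc(NS(=O)(=O)c4c(Br)nn(C)c4Cl)c3)C2)cc1OC1CCCC1` has not yet been measured. It differs from compound 3 in one place: 3-bromo-5-chloro-1-methyl-1H-pyrazol-4-yl in place of 2-fluorophenyl on a sulfonyl sulfur. All three measured steps concern the same position, the group on the sulfonyl sulfur, yet none of them yields a readable size, so the expectation rests on the limits alone. In this assay compound 4 is expected to give 15000 nM, in a range from 7000 nM to 50000 nM, most likely again as a limit. The step that the limit leaves unreadable from compound 3 to compound 4 is accordingly expected to show nothing beyond the usual scatter.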

Compound 4, half-maximal cytotoxic concentration: > 10000 nM
Compound 4: a limit, no number; the forecaster's own chance of this, stated with the estimate: 85%; the middle value does not contradict the limit.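

In this assay compound 4 gives > 10000 nM as a limit and not a number, so its steps from compound 1, compound 2 and compound 3 cannot be read: the limit of > 10000 nM in this assay, at which 4 of the 4 values shown sit.

The compounds shown leave open how much of each compound the cells actually tolerate, and whether changing the group on the sulfonyl sulfur alters that tolerance at all.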